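The source may report more compounds than this note shows. Statements on the series, on what has been measured and on what is new or still open speak of the compounds shown alone.

Compound 1, `O=C(O)c1cc(N2C(=O)C3=C(CCCC3)C2=O)c(F)cc1Cl`, gives 3160 nM in a functional assay on the whole organism with Scenedesmus acutus as the target, with a stated time of 20 h; a higher number here means a weaker inhibitor, a lower number a stronger inhibitor.
Compound 2, `O=C(O)c1cc(N2C(=O)C3=C(CCCC3)C2=O)ccc1Cl`, gives in this assay only a limit, > 100000 nM.
Compound 3, `CCCCOC(=O)c1cc(N2C(=O)C3=C(CCCC3)C2=O)c(F)cc1Cl`, gives 141 nM in this assay.

Compound 2 stands at the limit of this assay: its value is not a number but the point (the limit of > 100000 nM in this assay, at which 1 of the 3 values shown sits), and it is the only one of the three at that point. Compound 4, `CCCCCCCCOC(=O)c1cc(N2C(=O)C3=C(CCCC3)C2=O)ccc1Cl`, differs from compound 2 in one place: octyl in place of hydrogen on an oxygen next to a carbonyl group.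

Two measured steps are known. From compound 1 to compound 2 the change hydrogen in place of fluoro on an aromatic carbon gave an at least 31-fold higher number from compound 1 to compound 2 (1.50 log units; beyond the scatter). The step that bears directly on compound 4 is the other one: butyl in place of hydrogen on an oxygen next to a carbonyl group gave a 22-fold lower number from compound 1 to compound 3 (1.35 log units; beyond the scatter), a lowering of the number well beyond the scatter. Among the compounds with values here, the change from compound 2 to compound 4 is of the same kind, with octyl rather than butyl entering, so a lowering step is expected in this assay, though its size is uncertain because compound 2 itself sits at the limit of > 100000 nM in this assay, at which 1 of the 3 values shown sits, and the longer chain has no measured counterpart here.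

Compound 4 is therefore estimated at 15000 nM, with a range from 2000 nM to 100000 nM. This estimate means a step of an at least 6.6-fold lower number from compound 2 to compound 4 (0.82 log units; beyond the scatter), expected to lower the number.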

Compound 4, half-maximal inhibitory concentration: > 100000 nM
Compound 4: a limit, no number; the forecaster's own chance of this, stated with the estimate: 25%; middle value at least 6.6-fold (0.82 log units) from the limit.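

In this assay compound 4 gives > 100000 nM, a limit of the assay and not a number. Compound 2 and compound 4 thus stand at the same limit, and the step between them cannot be read: the limit of > 100000 nM in this assay, at which 2 of the 4 values shown sit.

The compounds shown leave open whether octyl in place of hydrogen on this oxygen changes the number at all, and how octyl and butyl compare on one shared core.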